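The source may report more compounds than this note shows. Statements on the series, on what has been measured and on what is new or still open speak of the compounds shown alone.

Compound 1 `COc1ncnc2c1c(-c1ccccc1)cn2[C@@H]1O[C@H](CO)[C@@H](O)[C@H]1O`: in a functional assay on HCT-116 cells (Homo sapiens), read by MTT assay, with a stated time of 72 h (a lower number here means a stronger inhibitor, a higher number a weaker inhibitor), compound 1 reaches only the assay limit, > 20000 nM.
Compound 2 `COc1ncnc2c1c(-c1ccsc1)cn2[C@@H]1O[C@H](CO)[C@@H](O)[C@H]1O`: in this assay compound 2 gives 140 nM.
Compound 3 `CSc1ncnc2c1c(-c1ccsc1)cn2[C@@H]1O[C@H](CO)[C@@H](O)[C@H]1O`: in this assay compound 3 reaches only the assay limit, > 20000 nM.

Among the compounds with values here, compound 2 stands alone as the only actual number among the three; the two other values are limits, namely (the limit of > 20000 nM in this assay, at which 2 of the 3 values shown sit). Both measured steps are large: an at least 140-fold lower number from compound 1 to compound 2 (2.15 log units; beyond the scatter), and an at least 140-fold higher number from compound 2 to compound 3 (2.15 log units; beyond the scatter). Compound 4 `COc1nc(N)nc2c1c(-c1ccsc1)cn2[C@@H]1O[C@H](CO)[C@@H](O)[C@H]1O` differs from compound 2 by amino in place of hydrogen on an aromatic carbon. Neither measured step touches this place: one exchanges phenyl for thiophen-3-yl, the other exchanges methoxy for methylsulfanyl, and both leave the carbon that now carries the amino untouched. The shown data therefore give no direct guide to the new change; they show only that the shared core of compound 2 answers strongly to alterations elsewhere. Without any step that bears on it, the step expected in this assay is taken as a 1.4-fold higher number from compound 2 to compound 4 (0.15 log units; within the scatter), not beyond the scatter, though with a wide margin on either side. On that basis compound 4 is estimated at 200 nM, within a range of 40 nM to 2000 nM.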

Compound 4, half-maximal inhibitory concentration: > 20000 nM
Compound 4 ended at the assay's limit (the forecaster's own chance of this, stated with the estimate: 15%); middle value at least 100-fold (2.00 log units) from the limit.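

In this assay, amino in place of hydrogen on an aromatic carbon, at the position between two ring nitrogen atoms, gives an at least 140-fold higher number from compound 2 to compound 4 (2.15 log units; beyond the scatter). Within the data shown here, this shows that a position left untouched by both earlier steps also matters in compound 2, so the phenyl and methoxy exchanges are not the only single changes that take the series from a measured number to the assay's limit. The value of compound 4, > 20000 nM, is a limit of the assay and not a number, so the step fixes only a minimum size, and compound 2 remains the only compound here with an actual number: the limit of > 20000 nM in this assay, at which 3 of the 4 values shown sit.

The compounds shown leave open whether any group other than amino can sit at this position and still give a measured number, for example a fluorine atom, a methyl group or a methylamino group. They also leave open whether the loss belongs to amino at this position in general or only to amino alongside the methoxy and thiophen-3-yl groups of compound 2, and how far beyond the limit compound 4 lies.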